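The source may hold more compounds than are shown below. What is called first, only, known or untested is meant among the compounds shown, and "the series" means these compounds.

Both measured compounds were tested in an ADME assay on cells (Fibroblast, Homo sapiens) for cytotoxicity, with a stated time of 48 h; on this read-out lower numbers stand for stronger inhibition and higher numbers for weaker inhibition. Compound 1 `O=[N+]([O-])c1ccc(CN2CCC(n3cc(CC(OCc4cc(-c5ccccc5)no4)c4ccc(Br)cc4)nn3)CC2)cc1` reaches only a limit of that read-out: in this assay compound 1 gives > 25000 nM, which is a limit and not a number. Compound 2 `O=[N+]([O-])c1ccc(CN2CCC(n3cc(CC(OCc4cc(-c5ccc(Br)cc5)no4)c4ccc(Br)cc4)nn3)CC2)cc1`, made by bromo in place of hydrogen on an aromatic carbon, stands at the same limit: in this assay compound 2 gives > 25000 nM, again a limit. The step that the two limits leave unreadable from compound 1 to compound 2 is therefore unreadable, since both values sit at the limit of > 25000 nM in this assay, at which 2 of the 2 values shown sit.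

Compound 3 `O=[N+]([O-])c1ccc(CN2CCC(n3cc(CC(OCc4cc(-c5ccc(F)cc5)no4)c4ccc(Br)cc4)nn3)CC2)cc1` differs from compound 2 by fluoro in place of bromo on an aromatic carbon. Going by the values given here, the only measured step, a step that the two limits leave unreadable from compound 1 to compound 2, gives no readable size, so nothing seen so far points to a change of cytotoxicity beyond the scatter; the expected step that the limit leaves unreadable from compound 2 to compound 3 is essentially none. Compound 3 is accordingly expected to give 30000 nM, within a range from 15000 nM to 100000 nM, most likely reported once more as a limit in this assay.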

Compound 3, half-maximal inhibitory concentration: > 25000 nM
Compound 3 gave a limit, no number (the forecaster's own chance of this, stated with the estimate: 85%); the middle value is on the limit's open side.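

No step among compound 1, compound 2 and compound 3 can be read in this assay, since all three values are limits and not numbers: the limit of > 25000 nM in this assay, at which 3 of the 3 values shown sit.

The compounds shown leave open whether hydrogen, bromo or fluoro at this place changes cytotoxicity at all, and at what concentration any of the three would reach half-maximal inhibition.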